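Methyl in Place of Nitro on the Phenyl Ring

The source may hold more compounds than are shown below. What is called first, only, known or untested is meant among the compounds shown, and "the series" means these compounds.

Of the compounds shown here, three sharing one core have been measured in an ADME assay on CCRF-CEM cells (Homo sapiens) for inhibition, read by cell counting; a lower number here means a stronger inhibitor, a higher number a weaker inhibitor. Compound 1 `CSc1nc(NCCCNc2ccnc3cc(Cl)ccc23)c(C#N)c(-c2ccccc2)n1` gives 4700 nM. Compound 2 `CSc1nc(-c2ccccc2)c(C#N)c(N2CCN(c3ccnc4cc(Cl)ccc34)CC2)n1` returns > 250000 nM, which is a limit of this assay rather than a number. That value is the single one sitting at the limit of > 250000 nM in this assay, at which 1 of the 3 values shown sits. Compound 3 `CSc1nc(NCCCCNc2ccnc3cc(Cl)ccc23)c(C#N)c(-c2ccc([N+](=O)[O-])cc2)n1` gives 760 nM, the lower of the two numbers reported; the nearest is compound 1, and the gap between them lies beyond the usual scatter.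

Compound 4 `CSc1nc(NCCCCNc2ccnc3cc(Cl)ccc23)c(C#N)c(-c2ccc(C)cc2)n1` differs from compound 3 only by methyl in place of nitro on an aromatic carbon of the six-membered carbon ring, para to a large group. Among the compounds with values here, no measured pair shows this same exchange, so its size is not known from the compounds in hand. Compound 4 is expected to be a somewhat weaker inhibitor than compound 3, with a step of a 2.1-fold higher number from compound 3 to compound 4 (0.32 log units; beyond the scatter) that may reach just beyond the scatter. Compound 4 is estimated at 1600 nM, within a range from 400 nM to 6500 nM.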

Compound 4, half-maximal inhibitory concentration: 4900 nM
Compound 4: middle estimate off by 3.1-fold (0.49 log units), on the low side, within the range that was stated.
By their numbers in this assay, from the lowest: compound 3; then compounds 1 and 4 (each within the scatter of the next). At a limit, above all of these: compound 2.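

In this assay the exchange of 4-nitrophenyl for 4-methylphenyl weakens inhibition, with a 6.4-fold higher number from compound 3 to compound 4 (0.81 log units; beyond the scatter) as the first measured size of any change at this place on the phenyl ring. Within the data shown here, no earlier pair of compounds differed in one place only, so this step is the first direct reading of what the group on this aromatic carbon, para to a large group, contributes. Of these two groups, nitro gives the stronger inhibitor, though a single exchange sets no trend.

Nothing measured here accounts for the size of this step. On these data alone, it remains open how an amine, a nitrile or a chlorine at the same place would compare with nitro and methyl, and whether the step would hold with a shorter chain.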